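Series notes: chain extension from compound 3 to compound 4

A few compounds are considered here, and "the series" means these few. Any claim that something is new, unique, unknown or untested is made for them only; others in the source may bear on it.

Measured so far in an assay on CHO cells for displacement of a labelled ligand from 5-hydroxytryptamine receptor 1B (Homo sapiens); on this read-out higher numbers stand for weaker inhibition and lower numbers for stronger inhibition:
compound 1 `c1c[nH]c(CN2CCN(CCCc3c[nH]c4ccc(-n5cnnc5)cc34)CC2)n1`: 36 nM
compound 2 `c1cc2[nH]cc(CCCN3CCNCC3)c2cc1-n1cnnc1`: 145 nM
compound 3 `CN1CCN(CCCc2c[nH]c3ccc(-n4cnnc4)cc23)CC1`: 309 nM

Compound 3 gives the highest number of the three. Its nearest neighbour is compound 2, the step being a 2.1-fold higher number from compound 2 to compound 3 (0.33 log units; beyond the scatter); the furthest is compound 1, with an 8.6-fold higher number from compound 1 to compound 3 (0.93 log units; beyond the scatter). The remaining step, a 4.0-fold higher number from compound 1 to compound 2 (0.61 log units; beyond the scatter), is also modest. All three steps change only the group on the amine nitrogen in the ring; none of them alters the chain that joins the ring to the core of compound 3.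

Compound 4 `CN1CCN(CCCCc2c[nH]c3ccc(-n4cnnc4)cc23)CC1` differs from compound 3 by (4-methylpiperazin-1-yl)methyl in place of 4-methylpiperazin-1-yl on a saturated chain carbon, three bonds along the chain from an aromatic carbon. Among the compounds with values here, no measured pair in the set varies this chain, so none of the three steps bears directly on the change. Within the data shown here, with no step to lean on, the working expectation is that the number in this assay stays near that of compound 3, giving an estimated step of a 1.0-fold higher number from compound 3 to compound 4 (0.02 log units; within the scatter), which is not beyond the scatter. Compound 4 is therefore expected to give about 320 nM, with a range from 100 nM to 1000 nM that allows for a modest move in either direction.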

Compound 4, half-maximal inhibitory concentration: 5100 nM
Compound 4: the middle estimate sits 16-fold (1.20 log units) below what was measured, and the stated range ends below it.
By their numbers in this assay, from the lowest: compound 1; then compound 2; then compound 3; then compound 4.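

At this position, on a saturated chain carbon, three bonds along the chain from an aromatic carbon, this assay responds strongly to (4-methylpiperazin-1-yl)methyl in place of 4-methylpiperazin-1-yl: the change gives a 17-fold higher number from compound 3 to compound 4 (1.22 log units; beyond the scatter) and is rated large, whereas every earlier step, all on the amine nitrogen in the ring, was modest. With (4-methylpiperazin-1-yl)methyl in place of piperazin-1-yl the move is a 35-fold higher number from compound 2 to compound 4 (1.55 log units; beyond the scatter) and is larger still, though this step also carries the methyl on the amine nitrogen, so it is not a pure chain change. Nothing in the data explains why the added chain carbon weakens inhibition so sharply, and the cause stays unassigned.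

The compounds shown leave open whether a shorter chain would lower the number relative to compound 3, and whether an ether oxygen or an amide within the chain would be tolerated. Also open, on these data alone, is whether (1H-imidazol-2-yl)methyl on the amine nitrogen, the group carried by compound 1, would recover inhibition on the longer chain of compound 4.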